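Benzyl on the ring nitrogen of two glycosylated pyrrolidinones

This account rests on a few compounds, and the source may have more. Where it says the series, first, only, none or still open, it means among the compounds named here.

Measured compounds:
compound 1 `O=C1C[C@@H](O[C@H]2O[C@H](CO)[C@@H](O)[C@H](O)[C@@H]2O)CN1`, in a functional assay on RAW264.7 cells (Mus musculus) for inhibition, read by Griess assay, with a stated time of 24 h (on this read-out higher numbers stand for weaker inhibition and lower numbers for stronger inhibition), compound 1 gives 108000 nM
compound 2 `C[C@@H]1O[C@@H](O[C@H]2CNC(=O)C2)[C@H](O)[C@H](O)[C@H]1O`, in this assay compound 2 gives 116000 nM
compound 3 `O=C1C[C@@H](O[C@H]2O[C@H](CO)[C@@H](O)[C@H](O)[C@@H]2O)CN1Cc1ccccc1`, in this assay compound 3 gives 97200 nM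

All three numbers lie close together. Compound 1 and compound 2 share the five-membered lactam but carry different sugars; the difference between the two cores is not broken down here. Compound 3 arises from compound 1 by one change, (benzyl in place of hydrogen on an amide-type nitrogen in a ring), and that step made a 1.1-fold lower number from compound 1 to compound 3 (0.05 log units; within the scatter).

The unmeasured compound 4 `C[C@@H]1O[C@@H](O[C@@H]2CC(=O)N(Cc3ccccc3)C2)[C@H](O)[C@H](O)[C@H]1O` arises from compound 2 by the same change, (benzyl in place of hydrogen on an amide-type nitrogen in a ring), at a place described in the same words as before. Among the compounds with values here, since the only example of this change, from compound 1 to compound 3, gave a 1.1-fold lower number from compound 1 to compound 3 (0.05 log units; within the scatter), the expected step from compound 2 to compound 4 in this assay is estimated as a 1.1-fold lower number from compound 2 to compound 4 (0.04 log units; within the scatter). Resting on compound 2 with 116000 nM, compound 4 is expected to come out near 105000 nM, likely between 50000 nM and 220000 nM.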

Compound 4, half-maximal inhibitory concentration: 56000 nM
Estimate against measurement, compound 4: 1.9-fold (0.27 log units) above, within the range that was stated.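

In this assay, benzyl in place of hydrogen on the amide-type nitrogen gave a 2.1-fold lower number from compound 2 to compound 4 (0.32 log units; beyond the scatter), a modest step beyond the scatter, whereas the earlier step on the core of compound 1 lay within it, yet the two steps themselves cannot be told apart: the same change on two cores in this assay, a 1.1-fold lower number (0.05 log units; within the scatter) from compound 1 to compound 3 and a 2.1-fold lower number (0.32 log units; beyond the scatter) from compound 2 to compound 4, 1.9-fold (0.27 log units) apart, within the scatter of two such steps

The series therefore gives no sign that this change behaves differently on the two cores, and a shared effect remains compatible with the numbers. Within the data shown here, with only two steps, however, this does not show that the effect carries over equally, nor does it establish a general rule for other cores.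

The compounds shown leave open whether a longer chain on the same nitrogen, or an amine or a carboxylic acid on the benzyl ring, would behave as benzyl does. They also leave open whether the step would hold on a core bearing a third sugar.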